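This account rests on a few compounds, and the source may have more. Where it says the series, first, only, none or still open, it means among the compounds named here.

Measured so far in a functional assay on HT-29 cells (Homo sapiens) for cytotoxicity, read by sulforhodamine B assay; on this read-out higher numbers stand for weaker inhibition of growth and lower numbers for stronger inhibition of growth:
compound 1 `CC1=CC[C@@H]([C@@](C)(O)CCCC(C)(C)NC(=S)N/N=C\c2ccc(C)cc2)CC1` gives 80400 nM
compound 2 `COc1ccc(/C=N\NC(=S)NC(C)(C)CCC[C@](C)(O)[C@@H]2CC=C(C)CC2)cc1` gives 35200 nM

Compound 1 stands highest of these two numbers, with compound 2 the nearer one: a 2.3-fold lower number from compound 1 to compound 2 (0.36 log units; beyond the scatter). Compound 3 `CC1=CC[C@@H]([C@@](C)(O)CCCC(C)(C)NC(=S)N/N=C\c2ccc(Cl)cc2)CC1` differs from compound 1 by chloro in place of methyl on an aromatic carbon. Within the data shown here, the only step that bears on this change is the one from compound 1 to compound 2, methoxy in place of methyl on an aromatic carbon, which moved the number modestly; a chloro in that place has no measured counterpart. Compound 3 is expected to show a step of similar modest size downward, a 1.6-fold lower number from compound 1 to compound 3 (0.21 log units; within the scatter). Compound 3 is estimated at 50000 nM, with a range from 20000 nM to 130000 nM.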

Compound 3, concentration for total growth inhibition: 22600 nM
Compound 3: middle estimate off by 2.2-fold (0.34 log units), on the high side; the range from low to high includes it.
By their numbers in this assay, from the lowest: compounds 3 and 2 (each within the scatter of the next); then compound 1.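

Replacing the methyl with chloro gives a 3.6-fold lower number from compound 1 to compound 3 (0.55 log units; beyond the scatter) in this assay, so a second group at this position, after methoxy, goes with a lower number than methyl. Chloro and methoxy are not separated, since the step between them is a 1.6-fold lower number from compound 2 to compound 3 (0.19 log units; within the scatter). Nothing available explains this result.

The compounds shown leave open how an amine or a carboxylic acid at this position would compare with chloro and methoxy. They also leave open whether a longer chain there would keep the number as low.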